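The compounds below may be only part of what the source reports. "The series", "measured", "known", "first", "only" and "open" are said of these compounds alone.

Working notes on the series in a functional assay on C8166 cells (Homo sapiens) for cytotoxicity, read by MTT assay, with a stated time of 72 h; a higher number here means that more compound is tolerated, a lower number that less compound is tolerated. Compound 1 (`Cc1nc2ccccc2n(CC(=O)N/N=C/c2ccc(N(C)C)cc2)c1=O`) gives 355000 nM. Compound 2 (`Cc1ccc(S(=O)(=O)N2CC3(C[C@H]2C(=O)N/N=C/c2ccccc2[N+](=O)[O-])SCCS3)cc1`) gives 65000 nM, the lower of the two numbers in hand, and its gap to compound 1 lies beyond the usual scatter. Compound 3 (`C/C(=N\NC(=O)Cn1c(=O)c(C)nc2ccccc21)c1ccccc1Cl`) reads > 543000 nM, which is a limit and not a number.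

Compound 4 (`Cc1ccc(S(=O)(=O)N2CC3(C[C@H]2C(=O)NN)SCCS3)cc1`) has not yet been measured. The change from compound 2 is one nitrogen atom in place of a group of 11 heavy atoms (7 carbon, 2 nitrogen, 2 oxygen; one six-membered aromatic ring of carbon only), on an amide-type nitrogen: an amino group replaces the larger group on an amide-type nitrogen. Within the data shown here, no measured pair isolates this change, so the size of the step remains poorly constrained. Among the measured compounds shown here, because compound 2 sits at 65000 nM, the lowest number so far, a moderate step to a higher number, beyond the scatter, is expected. The expected change is a 2.5-fold higher number from compound 2 to compound 4 (0.39 log units; beyond the scatter). Compound 4 is estimated at 160000 nM, with an expected range from 50000 nM to 500000 nM.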

Compound 4, half-maximal cytotoxic concentration: > 519000 nM
Compound 4: no number, only a limit (the forecaster's own chance of this, stated with the estimate: 30%); middle value at least 3.2-fold (0.51 log units) from the limit.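

In this assay compound 4 reads > 519000 nM and that reading is a limit, not a number. Amino in place of the group of 11 heavy atoms, on the amide-type nitrogen, is the first single change the series isolates, and it moves the reading beyond the scatter (an at least 7.9-fold higher number from compound 2 to compound 4 (0.90 log units; beyond the scatter)). The full size of this step cannot be given because the reading for compound 4 stops at the limit: the limit of > 519000 nM in this assay, at which 1 of the 4 values shown sits.

As far as these compounds go, whether an acetyl or a methyl group on that amide-type nitrogen would give a reading closer to compound 2 or to compound 4 remains open. A single pair also leaves open whether the step would carry over to the core of compound 1 or whether it is specific to the shared core of compound 2 and compound 4.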